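Swapping an aryl ether for a benzylamine on a diamine core

The compounds below may be only part of what the source reports. "The series", "measured", "known", "first", "only" and "open" are said of these compounds alone.

Compound 1 `Nc1cc(N)c2nc(-c3ccccc3)c(Oc3ccc(Cl)c(Cl)c3)nc2c1` was tested in a functional assay on NCI-H322M cells (Homo sapiens) for inhibition, read by sulforhodamine B assay, with a stated time of 48 h; a lower number here means that less compound is tolerated, a higher number that more compound is tolerated. In this assay compound 1 gives only a limit, < 100000 nM, and not a number. Compound 2 `COc1cc(CNc2nc3cc(N)cc(N)c3nc2-c2ccccc2)cc(OC)c1OC` likewise gives only a limit in this assay, < 50200 nM. Compound 3 `CCOC(=O)[C@H](CCC(=O)O)NC(=O)c1ccc(Oc2nc3cc(N)cc(N)c3nc2-c2ccccc2)cc1` also reaches only a limit in this assay, < 100000 nM. Compound 1 thus stands at the limit of < 100000 nM in this assay, at which 2 of the 3 values shown sit, while compound 2 sits at the limit of < 50200 nM in this assay, at which 1 of the 3 values shown sits; none of the three compounds has a numerical value in this assay.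

Compound 4 `Nc1cc(N)c2nc(-c3ccccc3)c(NCc3ccc(F)cc3)nc2c1` differs from compound 1 in one place: (4-fluorobenzyl)amino in place of 3,4-dichlorophenoxy on an aromatic carbon. No measured pair differing in one place is available, so the size of this step cannot be read from the three compounds shown. The expected step from compound 1 to compound 4 in this assay is a step that the limit leaves unreadable from compound 1 to compound 4, which is not beyond the scatter of the assay. Compound 4 is therefore estimated at 60000 nM in this assay, within a range from 15000 nM to 100000 nM, with a fair chance that only a limit is reported again.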

Compound 4, concentration lethal to 50% of the cells: 40700 nM
Beside the measured number, compound 4's estimate is 1.5-fold (0.17 log units) above it, within the range that was stated.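

Within the data shown here, compound 4 now has a numerical value, but compound 1 has only a limit, so no step from compound 1 to compound 4 can be read. The compounds shown leave open how large this swap of (4-fluorobenzyl)amino for 3,4-dichlorophenoxy is, and in which direction it runs.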